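From compound 2 to compound 4: methyl becomes trifluoromethyl

This account rests on a few compounds, and the source may have more. Where it says the series, first, only, none or still open, it means among the compounds named here.

Measured in a functional assay on CWR22R cells (Homo sapiens) for antiproliferative activity, with a stated time of 96 h; a lower number here means a stronger inhibitor, a higher number a weaker inhibitor:
- Compound 1 `Cc1cc(=O)oc2cc(OCC(=O)c3ccc(C#N)cc3)ccc12`: > 100000 nM, a limit
- Compound 2 `Cc1cc(=O)oc2cc(OCC(=O)c3ccc(C(F)(F)F)cc3)ccc12`: > 100000 nM, a limit
- Compound 3 `O=C(COc1ccc2c(C(F)(F)F)cc(=O)oc2c1)c1cc(C(F)(F)F)cc(C(F)(F)F)c1`: "not active" (no number reported)

Compound 2 has only a limit and no true number, and it stands at the limit of > 100000 nM in this assay, at which 2 of the 3 values shown sit. Compound 4 `O=C(COc1ccc2c(C(F)(F)F)cc(=O)oc2c1)c1ccc(C(F)(F)F)cc1` has trifluoromethyl in place of methyl on an aromatic carbon, opposite the ring oxygen: trifluoromethyl in place of methyl on an aromatic carbon. Within the data shown here, the one measured step, a step that the two limits leave unreadable from compound 1 to compound 2, gives no size to carry over. Compound 3, with that same trifluoromethyl on the core, gives "not active" (no number reported). No clear gain is therefore expected in this assay, and the expected change is a number no higher from compound 2 to compound 4 (the limit leaves the size open). The estimate for compound 4 is 100000 nM, with an expected range from 20000 nM to 200000 nM.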

Compound 4, half-maximal inhibitory concentration: "not active" (no number reported)
Nothing numeric was reported for compound 4; the estimate stays without a comparison.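

No step can be read from compound 2 to compound 4, since compound 4 is reported only as "not active", with no number. None of the compounds shown has a true number, leaving open whether trifluoromethyl in place of methyl changes potency at all.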